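Cytotoxicity of a difluoromethoxy analogue on a shared core

The source may report more compounds than this note shows. Statements on the series, on what has been measured and on what is new or still open speak of the compounds shown alone.

The series shares one core, carried by compound 1 `Cc1ccc2[nH]c(=O)c(CN(CCCO)Cc3ccc(C(C)(C)C)cc3)cc2c1`, compound 2 `COCOc1ccc(CN(Cc2ccc(C(C)(C)C)cc2)Cc2cc3cc(C)ccc3[nH]c2=O)cc1` and compound 3 `Cc1ccc2[nH]c(=O)c(CN(Cc3ccc(C(N)=O)cc3)Cc3ccc(C(C)(C)C)cc3)cc2c1`. In a toxicity assay on MDCK cells (Canis lupus familiaris) for cytotoxicity, read by crystal violet staining, with a stated time of 48 h (on this read-out lower numbers stand for higher toxicity in this test and higher numbers for lower toxicity in this test), compound 1 reaches only the limit > 10000 nM. In this assay compound 2 gives 6400 nM. Compound 3 likewise stops at the limit > 5000 nM in this assay. The step of an at least 1.5-fold lower number from compound 1 to compound 2 (0.19 log units; that floor lies within the scatter) is the only one that can be read, and it stays within the scatter; the steps a step that the two limits leave unreadable from compound 1 to compound 3 and a step that the limit leaves unreadable from compound 2 to compound 3 cannot be sized, since the limit of > 10000 nM in this assay, at which 1 of the 3 values shown sits, and the limit of > 5000 nM in this assay, at which 1 of the 3 values shown sits, cap the values. Compound 3 therefore stands among the least toxic values shown, but without a number of its own.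

Compound 4 `Cc1ccc2[nH]c(=O)c(CN(Cc3ccc(OC(F)F)cc3)Cc3ccc(C(C)(C)C)cc3)cc2c1` differs from compound 3 by difluoromethoxy in place of carbamoyl on an aromatic carbon. Going by the values given here, no measured step bears directly on this change, and the steps that touch the same benzyl position all lie within the scatter or at a limit. The step that the limit leaves unreadable from compound 3 to compound 4 is therefore expected to be small, with no direction favoured beyond the scatter. Compound 4 is estimated at 8000 nM, in the range 3000 nM to 20000 nM, in this assay.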

Compound 4, half-maximal cytotoxic concentration: > 5000 nM
Compound 4 ended at the assay's limit; the forecaster's own chance of this, stated with the estimate: 55%; the middle value is on the limit's open side.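

In this assay compound 4 gives only a limit of the assay, > 5000 nM, so no step linking it to compound 1, compound 2 or compound 3 can be read: the limit of > 5000 nM in this assay, at which 2 of the 4 values shown sit.

The compounds shown leave open whether difluoromethoxy in place of carbamoyl shifts the cytotoxic concentration at all.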